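The source may report more compounds than this note shows. Statements on the series, on what has been measured and on what is new or still open speak of the compounds shown alone.

Measured in an assay on CHO cells for displacement of a labelled ligand from Neuronal acetylcholine receptor; alpha3/beta4 (Homo sapiens), read by scintillation counting, with a stated time of 2 h; on this read-out lower numbers stand for stronger inhibition and higher numbers for weaker inhibition:
Compound 1, `C[C@@H]1C[C@H]1C(=O)N1CC2CNCC2C1`: compound 1 gives 360 nM.
Compound 2, `O=C(c1ccco1)[C@H]1C[C@H]2CNC[C@H]2C1`: compound 2 gives 2200 nM.
Compound 3, `O=C(C1CC1)[C@H]1C[C@@H]2CNC[C@@H](C2)C1`: compound 3 gives 4100 nM.

Compound 3 has the highest number of the three. Its nearest neighbour is compound 2, whose value differs from it by a margin within the usual scatter, so no order between the two can be read. Compound 1 stands furthest away, with a lower number beyond the scatter. Compound 4, `CCCNC(=O)[C@H]1C[C@@H]2CNC[C@@H](C2)C1`, differs from compound 3 by propylamino in place of cyclopropyl on a carbonyl carbon. For the measured compounds named here, no measured pair shows this change, so there is no step to size it from. Compound 2 at 2200 nM and compound 3 at 4100 nM sit close together despite different cores, which gives no reason to expect a large move. The expected step of a 1.0-fold lower number from compound 3 to compound 4 (0.01 log units; within the scatter) is none beyond the scatter. Compound 4 is estimated at 4000 nM, within 1500 nM to 12000 nM.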

Compound 4, inhibition constant: 4000 nM
Estimate against measurement, compound 4: no gap at the digits printed; measured number inside the range.
By their numbers in this assay, from the lowest: compound 1; then compounds 2, 4 and 3 (each within the scatter of the next).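

Putting propylamino in place of cyclopropyl on a carbonyl carbon gives a 1.0-fold lower number from compound 3 to compound 4 (0.01 log units; within the scatter) on the shared core. For the compounds shown here, this is the first pair here that differs in one place, and it shows that an open chain carrying the amide hydrogen and a three-membered ring cannot be told apart at this position. Nothing in the data accounts for this result.

Going by these compounds, whether a longer chain such as hexylamino or a carboxylic acid on this carbonyl carbon would also match compound 3 stays open. So does whether the same exchange would give a similar step on the core of compound 1.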